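From ethyl to isopropyl on the amide nitrogen

The source may hold more compounds than are shown below. What is called first, only, known or untested is meant among the compounds shown, and "the series" means these compounds.

Measured in a functional assay on cells (B cell, Homo sapiens) for inhibition, read by thymidine incorporation, with stated times of 30 min and 72 h; on this read-out higher numbers stand for weaker inhibition and lower numbers for stronger inhibition:
- compound 1 `C[C@H](Nc1ncnc(N)c1C#N)c1nc2ccc(F)cc2c(C(N)=O)c1-c1ccccc1`: 1.8 nM
- compound 2 `CNC(=O)c1c(-c2ccccc2)c([C@H](C)Nc2ncnc(N)c2C#N)nc2ccc(F)cc12`: 1.9 nM
- compound 3 `CCNC(=O)c1c(-c2ccccc2)c([C@H](C)Nc2ncnc(N)c2C#N)nc2ccc(F)cc12`: 1.2 nM

At 1.2 nM, compound 3 lies within the scatter of both other compounds. Compound 4 `CC(C)NC(=O)c1c(-c2ccccc2)c([C@H](C)Nc2ncnc(N)c2C#N)nc2ccc(F)cc12` changes ethyl to isopropyl, with methyl in place of hydrogen on a saturated chain carbon bound to an amide-type nitrogen and a saturated chain carbon. Among the measured compounds shown here, the closest precedent is the same kind of addition one carbon earlier, a 1.6-fold lower number from compound 2 to compound 3 (0.20 log units; within the scatter). The amide substitutions a 1.1-fold higher number from compound 1 to compound 2 (0.02 log units; within the scatter) and a 1.5-fold lower number from compound 1 to compound 3 (0.18 log units; within the scatter) also bear on it. None of these steps leaves the scatter, so no step beyond the scatter is expected in this assay. The expected change is a 1.3-fold higher number from compound 3 to compound 4 (0.10 log units; within the scatter). For compound 4 the estimated value is 1.5 nM, with an expected range from 0.7 nM to 3.5 nM.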

Compound 4, half-maximal inhibitory concentration: 1.3 nM
Compound 4: middle estimate off by 1.2-fold (0.06 log units), on the high side; the range from low to high includes it.
By their numbers in this assay, from the lowest: compounds 3, 4, 1 and 2 (each within the scatter of the next).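

In this assay, a methyl on the saturated chain carbon bound to the amide nitrogen, turning ethyl into isopropyl, stays within the scatter (a 1.1-fold higher number from compound 3 to compound 4 (0.03 log units; within the scatter)). Isopropyl also stays within the scatter when set against methyl (a 1.5-fold lower number from compound 2 to compound 4 (0.16 log units; within the scatter)) and against the amide hydrogen (a 1.4-fold lower number from compound 1 to compound 4 (0.14 log units; within the scatter)), so all four amide substituents shown give the same reading in this assay. No supporting evidence bears on this result.
From the compounds shown here alone, whether the flat reading extends to tert-butyl, a longer chain such as n-butyl, or a carboxylic acid on the amide nitrogen remains open.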